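A Methoxyphenyl Swap on the Shared Core

The source may hold more compounds than are shown below. What is called first, only, known or untested is meant among the compounds shown, and "the series" means these compounds.

Measured in a functional assay on MCF7 cells (Homo sapiens) for antiproliferative activity, read by sulforhodamine B assay, with a stated time of 48 h; on this read-out lower numbers stand for stronger inhibition and higher numbers for weaker inhibition
Compound 1 (`CCCN1CCN(c2ccc(S(=O)(=O)Oc3cccc(OC)c3)cc2)C1=O`) gives 6300 nM
Compound 2 (`CCCCN1CCN(c2ccc(S(=O)(=O)Oc3ccccc3)cc2)C1=O`) gives 8800 nM
Compound 3 (`CCCCN1CCN(c2ccc(S(=O)(=O)Oc3ccccc3OC)cc2)C1=O`) gives 3800 nM

For the measured compounds named here, compound 3 lies within the scatter of compound 1, and its only measured step is a 2.3-fold lower number from compound 2 to compound 3 (0.36 log units; beyond the scatter) with methoxy in place of hydrogen on an aromatic carbon. Going by the values given here, compound 4 (`CCCCN1CCN(c2ccc(S(=O)(=O)Oc3cccc(OC)c3)cc2)C1=O`) has 3-methoxyphenyl in place of 2-methoxyphenyl on an oxygen and no measured step tests this swap directly. Compound 1 carries the 3-methoxyphenyl group, and its value of 6300 nM sits within the scatter of compound 3. A small rise is therefore expected, with no step beyond the scatter. The expected change is a 1.3-fold higher number from compound 3 to compound 4 (0.10 log units; within the scatter) on this estimate. In this assay compound 4 is expected at 4800 nM with an estimated range from 2400 nM to 9000 nM as its bounds.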

Compound 4, half-maximal inhibitory concentration: 490 nM
For compound 4 the middle estimate is 9.8-fold (0.99 log units) above the measured one; measured number outside the range, below it.
By their numbers in this assay, from the lowest: compound 4; then compounds 3, 1 and 2 (each within the scatter of the next, the first and the last beyond it).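

In this assay the swap to 3-methoxyphenyl on the oxygen bound to the sulfonyl sulfur proves decisive (a 7.8-fold lower number from compound 3 to compound 4 (0.89 log units; beyond the scatter)), although the two compounds have the same atoms. Methoxy in place of hydrogen now brings a much larger gain than the earlier 2-methoxyphenyl case had shown (an 18-fold lower number from compound 2 to compound 4 (1.25 log units; beyond the scatter)). With 3-methoxyphenyl held constant, methyl in place of hydrogen on the saturated chain also counts (a 13-fold lower number from compound 1 to compound 4 (1.11 log units; beyond the scatter)).

Nothing here gives a cause for these steps.
On these data alone, whether a longer chain such as pentyl, or an amine or a carboxylic acid on this ring, would keep the gain remains open.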